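Cyclopentyl for isopropyl: a stability check on the core

The source may hold more compounds than are shown below. What is called first, only, known or untested is meant among the compounds shown, and "the series" means these compounds.

Compound 2 `COc1cc(-c2cnn3cc(OC)c(C(C)C)nc23)ccn1` was measured in an ADME assay on microsomes from liver (Rattus norvegicus) for metabolic stability, with a stated time of 60 min, tested at 1 uM (a higher number here means that more of the compound is left, a lower number that less of the compound is left), and gives 14%, the lowest of the three numbers. Compound 1 `COc1cc(-c2cnn3cc(OC)c(-c4cc(C)no4)nc23)ccn1` gives 62%, and compound 3 `COc1cn2ncc(-c3ccnc(OC(C)(C)C)c3)c2nc1-c1cnn(C)c1` gives 61%. Among the measured compounds shown here, the one step measured at a single place, a number 48 percentage points lower from compound 1 to compound 2 (beyond the scatter), shows that the group on this aromatic carbon can move the read-out strongly. Compound 4 `COc1cc(-c2cnn3cc(OC)c(C4CCCC4)nc23)ccn1` differs from compound 2 by cyclopentyl in place of isopropyl on an aromatic carbon. For the measured compounds named here, no measured step exchanges one such carbon-only group for another, so the expectation rests on compound 2 alone; a cyclopentyl entering for isopropyl is expected to give no step beyond the scatter, a number 4 percentage points lower from compound 2 to compound 4 (within the scatter). Compound 4 is therefore estimated at 10%, between 2% and 30%.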

Compound 4, percent of the compound remaining: 7%
The estimate for compound 4 lay 3 percentage points above the measured number; the range from low to high includes it.
By their numbers in this assay, from the lowest: compounds 4 and 2 (each within the scatter of the next); then compounds 3 and 1 (each within the scatter of the next).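

Cyclopentyl in place of isopropyl gives a number 7 percentage points lower from compound 2 to compound 4 (within the scatter) in this assay so these two carbon-only groups are not told apart at this position. Cyclopentyl in place of 3-methyl-1,2-oxazol-5-yl gives a number 55 percentage points lower from compound 1 to compound 4 (beyond the scatter) so the wide gap seen with isopropyl also appears with a second carbon-only group. Nothing available explains these numbers. On these data alone, whether an amine or a phenyl group on this aromatic carbon would give a number closer to that of compound 1 or to that of compound 4 remains open.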